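Swapping the aryl group on compound 3 for naphthalen-2-yl

The source may hold more compounds than are shown below. What is called first, only, known or untested is meant among the compounds shown, and "the series" means these compounds.

compound 1 `Cn1cncc1C(OCc1ccc(C#N)cc1-c1cccc(Cl)c1)c1ccc(C#N)nc1`: 2.1 nM
compound 2 `Cn1cncc1C(OCc1nc(N2CCC(O)CC2)c(C#N)cc1-c1cccc(Cl)c1)c1ccc(C#N)cc1`: 3.6 nM
compound 3 `Cn1cncc1C(OCc1ccc(C#N)nc1-c1ccc(OC(F)(F)F)cc1)c1ccc(C#N)cc1`: 4 nM

All of these numbers come from a functional assay on NIH3T3 cells (Mus musculus); a lower number here means that less compound is needed, a higher number that more compound is needed for the effect. In this small set, compound 3 gives 4 nM, which is within the usual scatter of the values of both compound 1 and compound 2. Among the compounds with values here, the three compounds therefore cannot be ranked on these numbers, and no measured pair differs in only one place.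

The next compound to be tested is compound 4 `Cn1cncc1C(OCc1ccc(C#N)nc1-c1ccc2ccccc2c1)c1ccc(C#N)cc1`. It carries naphthalen-2-yl in place of 4-(trifluoromethoxy)phenyl on an aromatic carbon. The rest of compound 3 is kept, including the six-membered aromatic ring with 1 nitrogen that bears this group.

Within the data shown here, no measured step isolates this swap, so its effect in this assay cannot be read directly from the data. The expectation rests only on the closeness of the three values, with compound 3 at 4 nM as the starting point. No change beyond the scatter is expected, and any drift is expected to go slightly towards a higher number. The estimated step is a 1.3-fold higher number from compound 3 to compound 4 (0.10 log units; within the scatter). For compound 4 the expected value is 5 nM, with an estimated range of 1.5 nM to 20 nM.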

Compound 4, half-maximal effective concentration: 7.4 nM
The estimate for compound 4 lay 1.5-fold (0.17 log units) below the measured number, and the stated range covers the measured number.
By their numbers in this assay, from the lowest: compounds 1, 2, 3 and 4 (each within the scatter of the next, the first and the last beyond it).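

Within the data shown here, this is the first step that isolates a single place: on the aromatic carbon next to the ring nitrogen, naphthalen-2-yl in place of 4-(trifluoromethoxy)phenyl gives a 1.9-fold higher number from compound 3 to compound 4 (0.27 log units; within the scatter) in this assay. The two groups therefore cannot be told apart in this assay, even though the entering group has two six-membered aromatic rings of carbon only and no hydrogen-bond acceptor, whereas the leaving group has one such ring and one hydrogen-bond acceptor. The information available offers no explanation for this result.

As far as these compounds go, both groups are aromatic and uncharged, so it remains open whether an amine, a carboxylic acid or a small alkyl chain on this carbon would give a number beyond the scatter of compound 3. From the compounds shown here alone, it also remains open whether the same swap would give a similar step on the cores of compound 1 and compound 2, which differ from compound 3 in more than one place.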